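Methyl removal on the benzamide core of compound 1

This account rests on a few compounds, and the source may have more. Where it says the series, first, only, none or still open, it means among the compounds named here.

Measured so far:
compound 1 `Cc1cn(-c2cc(NC(=O)c3ccc(C)c(Nc4nc(-c5cccnc5)cs4)c3)cc(C(F)(F)F)c2)cn1` — 28 nM
compound 2 `Cc1ccc(C(=O)Nc2cccc(C(F)(F)F)c2)cc1Nc1nc(-c2cccnc2)cs1` — 3010 nM

In a functional assay on K562 cells (Homo sapiens) for antiproliferative activity (on this read-out higher numbers stand for weaker inhibition and lower numbers for stronger inhibition), compound 1 gives the lower of the two numbers; its nearest neighbour is compound 2, and the step of a 110-fold higher number from compound 1 to compound 2 (2.03 log units; beyond the scatter) is large. Among the compounds with values here, that step concerns the 4-methyl-1H-imidazol-1-yl group on the anilide ring and is the only change measured.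

The next step goes from compound 1 to compound 3 `Cc1cn(-c2cc(NC(=O)c3cccc(Nc4nc(-c5cccnc5)cs4)c3)cc(C(F)(F)F)c2)cn1`. The change is hydrogen in place of methyl on an aromatic carbon: methyl leaves and hydrogen enters, on an aromatic carbon of a six-membered aromatic ring of carbon only, ortho to a (4-(pyridin-3-yl)-1,3-thiazol-2-yl)amino group and para to a large group. Within the data shown here, no measured step bears on this change; the step from compound 1 to compound 2 sits on the other ring and gives no guide to the size or direction here. A small loss is taken as the working expectation.

For compound 3 the expected value in this assay is 100 nM, with a range from 30 nM to 400 nM; this estimate means the step of a 3.6-fold higher number from compound 1 to compound 3 (0.55 log units; beyond the scatter) is expected from compound 1 to compound 3.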

Compound 3, half-maximal inhibitory concentration: 3190 nM
Compound 3: the middle estimate sits 32-fold (1.50 log units) below what was measured; the whole stated range lies below it.
By their numbers in this assay, from the lowest: compound 1; then compounds 2 and 3 (each within the scatter of the next).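

Replacing methyl with hydrogen in this assay gives a 110-fold higher number from compound 1 to compound 3 (2.06 log units; beyond the scatter) and so shows that this aromatic carbon, ortho to a (4-(pyridin-3-yl)-1,3-thiazol-2-yl)amino group and para to a large group, is not indifferent to what it carries. Within the data shown here, until now the only measured change was the removal of the 4-methyl-1H-imidazol-1-yl group on the other ring, with a 110-fold higher number from compound 1 to compound 2 (2.03 log units; beyond the scatter) as its step; the low number of compound 1 is now seen to depend on the methyl as well, since each single removal gives a large step beyond the scatter. Nothing at hand explains why this methyl carries so much weight.

From the compounds shown here alone, whether the effect belongs to the methyl itself or could be kept by another group on the same carbon, such as a chlorine, an ethyl or a methoxy group, stays open. Also open is how the two changes combine, as the compounds shown include none with hydrogen at both places.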